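The compounds below may be only part of what the source reports. "The series", "measured", "known", "first", "only" and "open" are said of these compounds alone.

Of the compounds shown here, three have so far been measured in an assay on isolated protein for inhibition of kynurenine 3-monooxygenase (Rattus norvegicus); a higher number here means a weaker inhibitor, a lower number a stronger inhibitor. Compound 1 `O=[N+]([O-])c1cccc(-c2csc(NS(=O)(=O)c3ccc(Cl)c(Cl)c3)n2)c1` gives 120 nM in this assay. Compound 2 `COc1ccc(S(=O)(=O)Nc2nc(-c3cc(C(F)(F)F)ccc3F)cs2)cc1OC` gives 39 nM, a lower number than compound 1 and beyond the usual scatter, while the much smaller compound 3 `O=C(O)c1cc(-c2cccc([N+](=O)[O-])c2)on1` gives 2680 nM, a far higher number than compound 1, again beyond the scatter. Compound 1 therefore stands second highest of the three numbers, between the other two.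

Compound 4 `CC(C)c1ccc(S(=O)(=O)Nc2nc(-c3cccc([N+](=O)[O-])c3)cs2)cc1` has not yet been measured. It differs from compound 1 in a single place: 4-isopropylphenyl in place of 3,4-dichlorophenyl on a sulfonyl sulfur. Among the compounds with values here, no measured pair isolates this kind of exchange, so the size of the step can only be judged loosely from the spread of the three numbers. The exchange is expected to move the number upward by a modest amount, so the step from compound 1 to compound 4 is estimated at a 2.1-fold higher number from compound 1 to compound 4 (0.32 log units; beyond the scatter). Compound 4 is accordingly expected to give about 250 nM in this assay, with a likely range from 80 nM to 800 nM.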

Compound 4, half-maximal inhibitory concentration: 990 nM
Beside the measured number, compound 4's estimate is 4.0-fold (0.60 log units) below it; the whole stated range lies below it.
By their numbers in this assay, from the lowest: compound 2; then compound 1; then compound 4; then compound 3.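

Within the data shown here, this is the first pair in which only the group on the sulfonyl sulfur changes, and in this assay putting 4-isopropylphenyl in place of 3,4-dichlorophenyl brings an 8.3-fold higher number from compound 1 to compound 4 (0.92 log units; beyond the scatter). The position is therefore sensitive to this exchange, even though both groups are a six-membered aromatic ring of carbon only, with 0 hydrogen-bond donors, 0 hydrogen-bond acceptors and no net charge, and they hold 8 and 9 heavy atoms. No measurement shown here bears on why the number rises.

The exchange removes two chlorine atoms and adds an isopropyl group in one move, so the compounds shown leave open how much of the step belongs to each. Also open, on these data alone, is how the core of compound 1 would fare with a plain phenyl ring or a phenyl ring carrying a single chlorine or a nitrile on the sulfonyl sulfur.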